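The source may report more compounds than this note shows. Statements on the series, on what has been measured and on what is new or still open speak of the compounds shown alone.

Measured compounds:
compound 1 `Cc1ccc(/C=C2\CN(C(=S)SCc3cn(Cc4ccc(F)cc4)nn3)C/C(=C\c3ccc(C)cc3)C2=O)cc1` — 29300 nM
compound 2 `Cc1ccc(/C=C2\CN(C(=S)SCc3cn(Cc4cccc(Cl)c4)nn3)C/C(=C\c3ccc(C)cc3)C2=O)cc1` — 53400 nM
compound 3 `O=C1/C(=C/c2ccccc2F)CN(C(=S)SCc2cn(Cc3ccc(F)cc3)nn2)C/C1=C\c1ccccc1F` — 9900 nM

All three were run in a functional assay on 4T1 cells (Mus musculus) for cytotoxicity, read by MTT assay, with a stated time of 24 h; on this read-out lower numbers stand for stronger inhibition and higher numbers for weaker inhibition. Among the compounds with values here, compound 1 and compound 2 share one core; the single change between them is 3-chlorophenyl in place of 4-fluorophenyl on a saturated chain carbon bound to an aromatic nitrogen. The step this change made is a 1.8-fold higher number from compound 1 to compound 2 (0.26 log units; within the scatter), so the two numbers are not separated here.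

Compound 3 carries a different core, and the difference between the two cores is not broken down here. In this assay compound 3 gives the lowest number of the three; its gap to compound 1 and its gap to compound 2 both lie beyond the scatter.

Compound 4 `O=C1/C(=C/c2ccccc2F)CN(C(=S)SCc2cn(Cc3cccc(Cl)c3)nn2)C/C1=C\c1ccccc1F` is not yet measured. It stands to compound 3 as compound 2 stands to compound 1: the change is 3-chlorophenyl in place of 4-fluorophenyl on a saturated chain carbon bound to an aromatic nitrogen, the same kind of change on the same place. Within the data shown here, the only guide is the one earlier step, which was within the scatter, so a small step is expected here as well, with the direction taken from that pair. The estimate for compound 4 in this assay is 16000 nM, between 7000 nM and 40000 nM, which corresponds to an expected step of a 1.6-fold higher number from compound 3 to compound 4 (0.21 log units; within the scatter).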

Compound 4, half-maximal inhibitory concentration: > 100000 nM
Compound 4 gave a limit, no number; the forecaster's own chance of this, stated with the estimate: 5%; at least 6.2-fold (0.79 log units) between middle value and limit.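

In this assay, the change from 4-fluorobenzyl to 3-chlorobenzyl gives an at least 10-fold higher number from compound 3 to compound 4 (1.00 log units; beyond the scatter). Going by these compounds, compound 4 stands at a limit, > 100000 nM, not a number, so the full size of this step is unknown. The size of the change does not carry over unchanged from one core to the other, although two pairs establish no rule for the series and do not show why the cores differ: the same change on two cores in this assay, a 1.8-fold higher number (0.26 log units; within the scatter) from compound 1 to compound 2 and an at least 10-fold higher number (1.00 log units; beyond the scatter) from compound 3 to compound 4, at least 5.5-fold (0.74 log units) apart, beyond the scatter of two such steps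

On these data alone, only 4-fluorophenyl and 3-chlorophenyl are compared at this place, so it remains open whether the large step belongs to the chlorine, to the position printed in the group's name, or to the particular pairing with the core of compound 3. A plain unsubstituted phenyl, or a phenyl carrying a methoxy group or an amine, on the same saturated chain carbon and on both cores would test how far the difference between the cores extends.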